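This account rests on a few compounds, and the source may have more. Where it says the series, first, only, none or still open, it means among the compounds named here.

Measured in a functional assay on the whole organism with Mus musculus as the target; a higher number here means that more compound is needed for the effect, a lower number that less compound is needed:
Compound 1 `O=C(/C=C/c1cccc(C(F)(F)F)c1)NCCO`: 117 mg/kg
Compound 2 `CN(C)C(=O)CCC(=O)c1cccc(C(F)(F)F)c1`: > 50 mg/kg

In this assay compound 2 stands at > 50 mg/kg as a limit of the assay and not a number. Among the measured compounds shown here, compound 2 therefore has no exact position relative to compound 1, and the series so far offers only one numerical value.

Compound 3 `CC(C)NC(=O)CCC(=O)c1cccc(C(F)(F)F)c1` is the next case. The change from compound 2 is isopropylamino in place of dimethylamino on a carbonyl carbon, with isopropylamino in place of dimethylamino on a carbonyl carbon. For the measured compounds named here, no measured pair shows the size of this change, so no shift beyond the scatter is expected in this assay. The estimated step that the limit leaves unreadable from compound 2 to compound 3 is therefore a working figure only. For compound 3 the expected value is 70 mg/kg within an estimated range of 25 mg/kg to 180 mg/kg, and the assay may again report only a limit.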

Compound 3, dose for half-maximal effect: > 200 mg/kg
Compound 3: a limit, no number; the forecaster's own chance of this, stated with the estimate: 35%; middle value at least 2.8-fold (0.45 log units) away from the limit.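

In this assay compound 3 gives > 200 mg/kg, a limit of the assay and not a number. Compound 2 gives > 50 mg/kg, also a limit. No step can be read between compound 2 and compound 3. The compounds shown leave open what size of shift, if any, isopropylamino in place of dimethylamino on a carbonyl carbon produces.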